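The source may report more compounds than this note shows. Statements on the series, on what has been measured and on what is new or still open speak of the compounds shown alone.

Measured in a functional assay on HeLa cells (Homo sapiens) for inhibition, read by CCK-8 assay, with a stated time of 72 h, tested at 2 uM (a lower number here means less inhibition of growth, a higher number more inhibition of growth at the concentration tested), so far:
- compound 1 `Cc1cc(C)cc(SCc2ccc(/C=C/C(=O)Nc3ccccc3N)cc2)c1` gives 11.7%
- compound 2 `Nc1ccccc1NC(=O)/C=C/c1ccc(CSc2cccc(F)c2)cc1` gives 2.25%
- compound 3 `COc1ccc(SCc2ccc(C(=O)Nc3ccccc3N)cc2)cc1` gives 35%

Compound 2 sits at the low end of these numbers together with compound 1. Within the data shown here, compound 3 stands clearly higher than both, but no step that changes only one place connects it to them.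

The next structure is compound 4 `Cc1ccc(SCc2ccc(/C=C/C(=O)Nc3ccccc3N)cc2)cc1`, which has not yet been measured in this assay and differs from compound 2 in one place: 4-methylphenyl in place of 3-fluorophenyl on a sulfur. In words, this is 4-methylphenyl in place of 3-fluorophenyl on a sulfur.

Among the measured compounds shown here, one measured step bears on this change. It also swaps one substituted phenyl group for another on the same sulfur. That step is a number 9.5 percentage points lower from compound 1 to compound 2 (within the scatter) and it gives no sign that such swaps move the number much. No shift beyond the scatter is therefore expected, though a single step is thin evidence.

The estimated change is a number 5.8 percentage points higher from compound 2 to compound 4 (within the scatter) and it is expected to stay within the scatter.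

Compound 4 is expected at 8% with an estimated range from 0% to 22% in this measurement.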

Compound 4, percent growth inhibition at one concentration: 25.5%
The estimate for compound 4 lay 17.5 percentage points below the measured number, and the stated range ends below it.
By their numbers in this assay, from the lowest: compounds 2 and 1 (each within the scatter of the next); then compounds 4 and 3 (each within the scatter of the next).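

At this sulfur, the choice of phenyl group can clearly move the number in this assay: 4-methylphenyl in place of 3-fluorophenyl gives a number 23.3 percentage points higher from compound 2 to compound 4 (beyond the scatter) and 4-methylphenyl in place of 3,5-dimethylphenyl gives a number 13.8 percentage points higher from compound 1 to compound 4 (beyond the scatter) on the same sulfur. Methyl groups alone do not settle the matter, since compound 1, with 3,5-dimethylphenyl, stays within the scatter of compound 2, whereas compound 4, with 4-methylphenyl, does not. Nothing measured here explains this shift.

The compounds shown leave open whether a single methyl group must sit as it does in 4-methylphenyl, as 3-methylphenyl would test, and whether 4-chlorophenyl or 4-aminophenyl would read like it. They also leave open how a carboxylic acid on this phenyl ring would read.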